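The source may report more compounds than this note shows. Statements on the series, on what has been measured and on what is new or still open speak of the compounds shown alone.

The series shares the core of compound 1 `CC/C(C)=N\Nc1nc(-c2cccc([N+](=O)[O-])c2)cs1`, which in a functional assay, with a stated time of 30 min (on this read-out lower numbers stand for stronger inhibition and higher numbers for weaker inhibition), gives 1180000 nM. Compound 2 `CCC/C(C)=N\Nc1nc(-c2cccc([N+](=O)[O-])c2)cs1` gives 1200000 nM, and compound 3 `C=CCC/C(C)=N\Nc1nc(-c2cccc([N+](=O)[O-])c2)cs1` gives 1210000 nM. The steps among them read a 1.0-fold higher number from compound 1 to compound 2 (0.01 log units; within the scatter), a 1.0-fold higher number from compound 1 to compound 3 (0.01 log units; within the scatter) and a 1.0-fold higher number from compound 2 to compound 3 (0.00 log units; within the scatter). Compound 3 holds the highest of the three numbers, but its gaps to compound 2 and to compound 1 both lie within the scatter, so no separation among the three is claimed.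

Compound 4 `CCCCCC/C(C)=N\Nc1nc(-c2cccc([N+](=O)[O-])c2)cs1` differs from compound 3 by butyl in place of vinyl on a saturated chain carbon, two bonds along the chain from a carbon with a double bond to nitrogen. Going by the values given here, the steps that bear on this are the three chain changes at the same place, each within the scatter, so in this assay a step from compound 3 to compound 4 of no size beyond the scatter is expected, in neither direction. Compound 4 is accordingly estimated at 1200000 nM, with a range from 500000 nM to 3000000 nM. The expected step is a 1.0-fold lower number from compound 3 to compound 4 (0.00 log units; within the scatter).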

Compound 4, half-maximal inhibitory concentration: 1150000 nM
The estimate for compound 4 lay 1.0-fold (0.02 log units) above the measured number; the range from low to high includes it.
By their numbers in this assay, from the lowest: compounds 4, 1, 2 and 3 (each within the scatter of the next).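

In this assay, butyl on a saturated chain carbon, two bonds along the chain from a carbon with a double bond to nitrogen, reads a 1.1-fold lower number from compound 3 to compound 4 (0.02 log units; within the scatter) against vinyl and a 1.0-fold lower number from compound 1 to compound 4 (0.01 log units; within the scatter) against hydrogen. Propyl in place of hydrogen on a saturated chain carbon, three bonds along the chain from a carbon with a double bond to nitrogen, reads a 1.0-fold lower number from compound 2 to compound 4 (0.02 log units; within the scatter) and likewise shows no separation, so a saturated butyl group at this place joins the earlier chains within the scatter. No measured information bears on why these chain changes leave the read-out unseparated.

On these data alone, whether an amine or a carboxylic acid at this place would give a step beyond the scatter remains open. A chain longer than hexyl or a phenyl ring at this place is equally untested by the compounds shown.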